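The source may hold more compounds than are shown below. What is called first, only, known or untested is meant among the compounds shown, and "the series" means these compounds.

Among the compounds with values here, compound 2 `NCCCOc1ccc(CNc2nc3ccc(Oc4cccc(C(F)(F)F)c4)cc3s2)cc1` gives 144000 nM in an assay on SH-SY5Y cells for inhibition of Voltage-dependent N-type calcium channel subunit alpha-1B (Homo sapiens), read by FLIPR and calcium flux, with stated times of 600 s and 300 s, in the presence of a further agent that is not named here (on this read-out higher numbers stand for weaker inhibition and lower numbers for stronger inhibition), the highest of the two numbers measured so far, while compound 1 `NCCCOc1ccc(CNc2nc3ccc(Oc4ccc(C(F)(F)F)cc4)cc3s2)cc1` gives 59000 nM. Compound 3 `NCCCOc1ccc(CNc2nc3ccc(Oc4ccccc4)cc3s2)cc1` carries hydrogen in place of trifluoromethyl on an aromatic carbon. Within the data shown here, the only measured step, a 2.4-fold higher number from compound 1 to compound 2 (0.39 log units; beyond the scatter), shifts the trifluoromethyl rather than removing it, so it bears on this change only loosely, and it was modest. A step in this assay beyond the scatter is therefore not expected in either direction. Compound 3 is estimated at 110000 nM, with a range from 40000 nM to 300000 nM, which means an expected step of a 1.3-fold lower number from compound 2 to compound 3 (0.12 log units; within the scatter).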

Compound 3, half-maximal inhibitory concentration: 218000 nM
Estimate against measurement, compound 3: 2.0-fold (0.30 log units) below, and the stated range covers the measured number.
By their numbers in this assay, from the lowest: compound 1; then compounds 2 and 3 (each within the scatter of the next).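

In this assay, taking the 3-(trifluoromethyl) group off the phenyl gives a 1.5-fold higher number from compound 2 to compound 3 (0.18 log units; within the scatter), so at this place the group's loss cannot be told apart from repeat-measurement noise. Taking off the 4-(trifluoromethyl) group instead gives a 3.7-fold higher number from compound 1 to compound 3 (0.57 log units; beyond the scatter), so only from this place does removal give a real, though modest, change. Nothing measured here explains why the two places differ. On these data alone, whether a chlorine, a methoxy or an amine on this ring would give a lower number stays open, and so does whether either place can give a much lower number at all.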